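A few compounds are considered here, and "the series" means these few. Any claim that something is new, unique, unknown or untested is made for them only; others in the source may bear on it.

Measured in an assay on HEK293 cells for positive allosteric modulation of metabotropic glutamate receptor 2 (Rattus norvegicus), read by thallium flux, with a stated time of 2.5 min; a higher number here means a larger maximal response, a lower number a smaller maximal response:

- compound 1 `COc1cc(C(=O)O)ccc1OCCCCOc1ccc(C(=O)CC(C)C)c(O)c1C`: 85.7%
- compound 2 `Cc1c(OCCCCOc2ccc(C(=O)O)cc2Cl)ccc(C(=O)CC2CCCC2)c1O`: 82.2%
- compound 3 `CCC(=O)c1ccc(OCCCCOc2ccc(F)c(C(=O)O)c2)c(C)c1O`: 66.6%

Compound 2 stands second of the three numbers. Its gap to compound 1 lies within the usual scatter, so the two cannot be told apart on these data. Its gap to compound 3 lies beyond the scatter, so compound 2 gives a clearly larger maximal response than compound 3.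

Compound 4 `Cc1cc(C(=O)O)ccc1OCCCCOc1ccc(C(=O)CC2CCCC2)c(O)c1C` has not yet been measured in this assay. It differs from compound 2 in one place: methyl in place of chloro on an aromatic carbon. For the measured compounds named here, no two measured compounds differ from each other in this way alone, so there is no measured step of the same kind to lean on; the three measured compounds differ in several places at once.

Chloro and methyl are each a single heavy atom without donors or acceptors, and the step from compound 2 to compound 4 is therefore expected to stay within the scatter, a number 2.2 percentage points lower from compound 2 to compound 4 (within the scatter). Compound 4 is thus estimated at 80%, with a range from 66% to 92%.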

Compound 4, largest response reached (reported as percent of maximum), in percent of the reference or control that the assay uses: 84.6%
Beside the measured number, compound 4's estimate is 4.6 percentage points below it, and the stated range covers the measured number.
By their numbers in this assay, from the lowest: compound 3; then compounds 2, 4 and 1 (each within the scatter of the next).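

In this assay, placing methyl in place of chloro on this aromatic carbon, ortho to a large group and meta to a carboxy group, gives a step that can be read on its own (a number 2.4 percentage points higher from compound 2 to compound 4 (within the scatter)). For the compounds shown here, this is the first comparison here in which only one place differs, and it shows that the 4-carboxy-2-chlorophenyl and 4-carboxy-2-methylphenyl forms cannot be told apart by their maximal response. Nothing available explains why these two groups give results so close together.

On these data alone, whether an amine, a hydroxyl group or a longer chain at this position would give a similar maximal response remains open. A single pair also leaves open whether the same swap would stay within the scatter with a different group on the ketone.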